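Branching the Amide Chain of a Naphthyl Channel Ligand

The source may hold more compounds than are shown below. What is called first, only, known or untested is meant among the compounds shown, and "the series" means these compounds.

Measured so far:
compound 1, `CCC(=O)Nc1c(C(O)(C(F)(F)F)C(F)(F)F)ccc2ccccc12`, 15 nM in an assay on LtK cells with ATP-sensitive inward rectifier potassium channel 11 (Homo sapiens) as the target; on this read-out lower numbers stand for an effect already at smaller amounts and higher numbers for an effect only at larger amounts of compound;
compound 2, `CCC(C)C(=O)Nc1c(C(O)(C(F)(F)F)C(F)(F)F)ccc2ccccc12`, 177000 nM in this assay.

Among the measured compounds shown here, compound 2 stands at the higher of the two numbers; the only step known, a 12000-fold higher number from compound 1 to compound 2 (4.07 log units; beyond the scatter), was large. Compound 3, `CCC(CC)C(=O)Nc1c(C(O)(C(F)(F)F)C(F)(F)F)ccc2ccccc12`, carries methyl in place of hydrogen on a saturated chain carbon, two bonds along the chain from a carbonyl carbon. For the measured compounds named here, no measured step matches this change. Going by the values given here, the one available step shows that growing the saturated chain near the carbonyl raised the number sharply, so a further gain in size is expected to leave compound 3 at a high number or raise it slightly, an expected step of a 1.7-fold higher number from compound 2 to compound 3 (0.23 log units; within the scatter). Compound 3 is therefore estimated at 300000 nM, between 80000 nM and 1500000 nM.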

Compound 3, half-maximal effective concentration: 4340 nM
Compound 3: middle estimate off by 69-fold (1.84 log units), on the high side, and the stated range ends above it.
By their numbers in this assay, from the lowest: compound 1; then compound 3; then compound 2.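

Adding one methyl, which turns sec-butyl into pentan-3-yl, gave a 41-fold lower number from compound 2 to compound 3 (1.61 log units; beyond the scatter) in this assay and so showed that a larger group at this position need not mean a higher number. The recovery is only partial, since replacing the ethyl of compound 1 with pentan-3-yl still gave a 290-fold higher number from compound 1 to compound 3 (2.46 log units; beyond the scatter) on the same read-out. Nothing available explains why the trend turns here.

As far as these compounds go, whether a cyclopentyl ring in place of pentan-3-yl, or an amine on the same saturated chain carbon, would behave like compound 3 or like compound 2 remains open.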